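A Bromo-Methoxyphenyl Swap Checked for Cell Toxicity

The source may hold more compounds than are shown below. What is called first, only, known or untested is meant among the compounds shown, and "the series" means these compounds.

Of the compounds shown here, two have so far been measured in an ADME assay on Vero cells (Chlorocebus sabaeus) for cytotoxicity, read by MTT assay, tested at 50 uM; a lower number here means a stronger effect, a higher number a weaker effect of the compound at the concentration tested. Compound 1 `CSc1ccc(C(=O)/C(=C/c2cccnc2)c2ccc(Cl)c(Cl)c2)cc1` gives 89.6%. Compound 2 `CCOC(=O)C(C(=O)c1ccc(OC)cc1)C(NC(C)=O)c1ccc(C(C)(C)C)cc1` gives 92.3%. Compound 2 stands nearest to compound 1, and the gap between the two numbers lies within the scatter, so the pair cannot be told apart: both compounds leave most of the cells alive at the concentration tested.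

Compound 3 `CCOC(=O)C(C(=O)c1ccc(OC)cc1)C(NC(C)=O)c1cc(OC)ccc1Br` has not yet been measured. It differs from compound 2 in one place: 2-bromo-5-methoxyphenyl in place of 4-(tert-butyl)phenyl on a saturated chain carbon bound to an amide-type nitrogen and a saturated chain carbon. The carbon that carries the change is bound to an amide-type nitrogen and to a saturated chain carbon, and the rest of the molecule stays as it is.

Within the data shown here, no measured pair shows what this kind of change does in this assay, so the expectation rests only on the two values already known, which both sit high. The expected step is a number 4.3 percentage points lower from compound 2 to compound 3 (within the scatter), small and not beyond the scatter in either direction. Compound 3 is therefore estimated to give 88% in this assay, with a range from 70% to 100%.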

Compound 3, a percentage reported as activity, at one concentration (the size of the read-out at that concentration, not a potency): 93.3%
Compound 3: the middle estimate sits 5.3 percentage points below what was measured, within the range that was stated.
By their numbers in this assay, from the lowest: compounds 1, 2 and 3 (each within the scatter of the next).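

In this assay, the saturated chain carbon that carries 4-(tert-butyl)phenyl now carries 2-bromo-5-methoxyphenyl, which gives a number 1 percentage points higher from compound 2 to compound 3 (within the scatter), the first step measured at this position. The two groups differ in their atoms, since the entering one carries an oxygen and a bromine and counts one hydrogen-bond acceptor against none, yet this assay cannot tell compound 2 and compound 3 apart, and both numbers stay high, so at this carbon the read-out tolerates this particular exchange of one aromatic ring for another. Nothing available explains why the number holds steady, and no supporting data bear on this result.

This is a single step at a single concentration, so it cannot show whether other groups would be tolerated as well. A primary amine or a carboxylic acid on the aromatic ring, or a longer chain in place of that ring at this carbon, might move the number beyond the scatter, and the compounds shown give no way to tell.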